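Replacing an Ethyl by a Difluoroethyl-Bearing Phenyl Ring

The source may hold more compounds than are shown below. What is called first, only, known or untested is meant among the compounds shown, and "the series" means these compounds.

Of the compounds shown here, three have been measured in a functional assay on HOS cells (Homo sapiens) for inhibition, read by CCK-8 assay, with a stated time of 72 h, tested at 1 uM; on this read-out higher numbers stand for more inhibition at the one concentration tested (going by the name of the read-out) and lower numbers for less inhibition. Compound 1 `COc1ccccc1N1C(=O)CSC1C(=O)NCCCCc1ccccc1` gives 0%, compound 2 `CCN1C(=O)CSC1c1cccc(C(=O)NCCCCc2ccccc2)c1` gives 6%, and compound 3 `O=C(NCCCCc1ccccc1)c1cccc(C2OCC(=O)N2c2cccc(F)c2)c1` gives 29%. Compound 2 thus stands second highest of the three: its nearest neighbour is compound 1, within the usual scatter, and its furthest is compound 3, which lies beyond the scatter above it.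

Compound 4 `CC(F)(F)c1cccc(N2C(=O)CSC2c2cccc(C(=O)NCCCCc3ccccc3)c2)c1` differs from compound 2 in one place: a group of 10 heavy atoms (8 carbon, 2 fluorine; one six-membered aromatic ring of carbon only) in place of a group of 2 heavy atoms (2 carbon; no ring), on an amide-type nitrogen in a ring. Among the measured compounds shown here, no step between measured compounds matches this change, so the expected size rests only on the three values shown; a modest rise in this assay, at most just beyond the scatter, is estimated, because compound 3 gives 29% with an aromatic ring on the same ring nitrogen. Compound 4 is therefore expected to give 18%, within 0% to 40%, which means an estimated step of a number 12 percentage points higher from compound 2 to compound 4 (beyond the scatter).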

Compound 4, a percentage reported as inhibition, at one concentration (the size of the read-out at that concentration, not a potency): 23%
The estimate for compound 4 lay 5 percentage points below the measured number; the range from low to high includes it.
By their numbers in this assay, from the lowest: compounds 1 and 2 (each within the scatter of the next); then compounds 4 and 3 (each within the scatter of the next).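

At the amide-type nitrogen in the ring of the shared core, the ethyl can give way to a much larger group carrying a six-membered aromatic ring, and in this assay the read-out is a number 17 percentage points higher from compound 2 to compound 4 (beyond the scatter). This single change therefore raises the inhibition at the one concentration tested, though the size of the step remains modest. Nothing shown here gives a reason for the rise.

Whether the phenyl ring alone accounts for the step, or the difluoroethyl on it contributes, remains open. So does how an unsubstituted phenyl, a methoxy-bearing phenyl or a carboxylic acid on that ring would read.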